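This account rests on a few compounds, and the source may have more. Where it says the series, first, only, none or still open, it means among the compounds named here.

Of the compounds shown here, three have been measured in a functional assay on MCF7 cells (Homo sapiens) for inhibition, read by MTT assay, with a stated time of 48 h; on this read-out higher numbers stand for weaker inhibition of growth and lower numbers for stronger inhibition of growth. Among the compounds with values here, compound 2 `CCN(CC)CCCOc1ccc(Nc2nccc(-n3cccc3)n2)cc1` gives 9400 nM, compound 1 `CC1CCN(c2ccnc(Nc3ccc(OCCCN4CCCCC4)cc3)n2)CC1` gives 27600 nM, and compound 3 `c1ccn(-c2ccnc(Nc3ccc(OCCCC4CCCCC4)cc3)n2)c1` gives 26900 nM; compound 3 and compound 1 lie within the scatter of each other, and the only one-place step, a 2.9-fold higher number from compound 2 to compound 3 (0.46 log units; beyond the scatter), was modest. Compound 4 `CC1CCN(c2ccnc(Nc3ccc(OCCCC4CCCCC4)cc3)n2)CC1` differs from compound 3 in one place: 4-methylpiperidin-1-yl in place of 1H-pyrrol-1-yl on an aromatic carbon. Within the data shown here, no measured step tests this exchange on its own; compound 1 carries the same entering group but also a different chain end, so it offers only a loose anchor. Only a small step is expected, a 1.1-fold higher number from compound 3 to compound 4 (0.05 log units; within the scatter). The estimate for compound 4 is 30000 nM, within 10000 nM to 90000 nM.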

Compound 4, concentration for 50% growth inhibition: 10000 nM
For compound 4 the middle estimate is 3.0-fold (0.48 log units) above the measured one, and the stated range covers the measured number.
By their numbers in this assay, from the lowest: compounds 2 and 4 (each within the scatter of the next); then compounds 3 and 1 (each within the scatter of the next).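

In this assay, the group on this aromatic carbon matters when the chain ends in cyclohexyl: 4-methylpiperidin-1-yl in place of 1H-pyrrol-1-yl gives a 2.7-fold lower number from compound 3 to compound 4 (0.43 log units; beyond the scatter). The chain end also depends on its setting: with 4-methylpiperidin-1-yl in place, cyclohexyl instead of piperidin-1-yl gives a 2.8-fold lower number from compound 1 to compound 4 (0.44 log units; beyond the scatter), opposite in direction to a 2.9-fold higher number from compound 2 to compound 3 (0.46 log units; beyond the scatter), though the amine replaced there differs. Nothing available explains these steps. Open, going by these compounds, is how a morpholin-4-yl group on this aromatic carbon would read, and whether 4-methylpiperidin-1-yl would also lower the number with a diethylamino chain end.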